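A few compounds are considered here, and "the series" means these few. Any claim that something is new, unique, unknown or untested is made for them only; others in the source may bear on it.

Measured compounds:
Compound 1, `O=C1/C(=C/c2cccc(Cl)c2)Cc2ccccc21`, in a functional assay on CCRF-CEM cells (Homo sapiens) for inhibition (a higher number here means a weaker inhibitor, a lower number a stronger inhibitor), gives 31800 nM.
Compound 2, `O=C1/C(=C/c2cccc(Br)c2)Cc2ccccc21`, in this assay gives 32400 nM.
Compound 3, `O=C1/C(=C/c2ccc(Cl)cc2)CCCc2ccccc21`, in this assay gives 15100 nM.

Compounds 1 and 2 share a core and differ in one place only: bromo in place of chloro on an aromatic carbon. That change made a 1.0-fold higher number from compound 1 to compound 2 (0.01 log units; within the scatter). Compound 3 is built on a different core; the difference between the two cores is not broken down here. Compound 3 carries the lowest number of the three, and its distance to compound 1 and to compound 2 lies beyond the scatter in each case.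

Compound 4, `O=C1/C(=C/c2ccc(Br)cc2)CCCc2ccccc21`, is not yet measured. It differs from compound 3 by bromo in place of chloro on an aromatic carbon. Among the measured compounds shown here, this is the same kind of change as the one from compound 1 to compound 2, but not the same: there the halogen sits meta to a large group, here para to a large group.

Since the earlier swap of bromo for chloro gave a 1.0-fold higher number from compound 1 to compound 2 (0.01 log units; within the scatter), the step from compound 3 to compound 4 in this assay is expected to be a 1.0-fold lower number from compound 3 to compound 4 (0.00 log units; within the scatter), a step within the scatter. Compound 4 is therefore estimated at 15000 nM, with a likely range from 8000 nM to 30000 nM.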

Compound 4, half-maximal inhibitory concentration: 17100 nM
For compound 4 the middle estimate is 1.1-fold (0.06 log units) below the measured one, within the range that was stated.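

In this assay, bromo in place of chloro on an aromatic carbon, para to a large group, gives a 1.1-fold higher number from compound 3 to compound 4 (0.05 log units; within the scatter), so on the core of compound 3 the swap leaves the read-out unresolved from that of the chloro compound. Set beside the earlier step, the swap carries from one core to the other with no difference that can be told apart: the same change on two cores in this assay, a 1.0-fold higher number (0.01 log units; within the scatter) from compound 1 to compound 2 and a 1.1-fold higher number (0.05 log units; within the scatter) from compound 3 to compound 4, 1.1-fold (0.05 log units) apart, within the scatter of two such steps. This shows only that the two halogens are interchangeable in these two pairs; the halogen also sits at a different place in each pair, so core and position are not separated, and nothing follows for a third core or for any other substituent.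

The compounds shown carry only chloro and bromo on that ring, so it stays open how an amine, a carboxylic acid or a methoxy group would read on either core. No pair shown differs in the core alone, so the effect of the core itself also stays open.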